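The compounds below may be only part of what the source reports. "The series", "measured", "known", "first", "only" and "open" are said of these compounds alone.

In an ADME assay on HepG2 cells (Homo sapiens) for cytotoxicity, with a stated time of 72 h (a higher number here means that more compound is needed for the effect, a lower number that less compound is needed), compound 1 `CSc1ccc(NC(=O)Nc2cc(C)nc3ccccc23)cc1` gives 16000 nM. Going by these compounds, compound 2 `Cc1cc(NC(=O)Nc2ccc(F)cc2)c2ccccc2n1` gives only a limit of the assay, > 25000 nM, so its true position is unknown. Compound 3 `COC(=O)c1ccc(NC(=O)Nc2cc(C)nc3ccccc23)cc1` carries methoxycarbonyl in place of fluoro on an aromatic carbon. Among the compounds with values here, the one measured step at this place is an at least 1.5-fold higher number from compound 1 to compound 2 (0.19 log units; that floor lies within the scatter), and it bears on this change only loosely. In this assay, a modest move to a lower number is therefore expected, and it may not clear the scatter. The expected step is an at least 1.2-fold lower number from compound 2 to compound 3 (0.09 log units; that floor lies within the scatter). Compound 3 is estimated at 20000 nM, with an expected range of 9000 nM to 35000 nM.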

Compound 3, half-maximal effective concentration: 20000 nM
Compound 3: middle estimate and measured number agree at the digits printed; the measured number falls inside the stated range.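

In this assay, methoxycarbonyl and methylsulfanyl on this aromatic carbon are not separated, with a 1.3-fold higher number from compound 1 to compound 3 (0.10 log units; within the scatter). Set against fluoro, the same change gives an at least 1.2-fold lower number from compound 2 to compound 3 (0.09 log units; that floor lies within the scatter). The value of compound 2 is only a limit of the assay, so that step gives a floor and not a size: the limit of > 25000 nM in this assay, at which 1 of the 3 values shown sits.

Going by these compounds, how far compound 2 truly lies from compound 3 stays open. Also open, on these data alone, is whether an amine, a carboxylic acid or a longer chain on this aromatic carbon would move the number beyond the scatter.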